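This account rests on a few compounds, and the source may have more. Where it says the series, first, only, none or still open, it means among the compounds named here.

Working notes on the series in a functional assay on NCI-H1993 cells (Homo sapiens) for inhibition, read by CCK-8 assay, with a stated time of 72 h; on this read-out higher numbers stand for weaker inhibition and lower numbers for stronger inhibition: compound 1 `CC(c1cc2cccnc2cc1F)n1cnc2ncc(-c3cnn(C)c3)nc21` gives 31.3 nM, compound 2 `CC(c1c(F)cc2ncccc2c1F)n1cnc2ncc(-c3cnn(C)c3)nc21` gives 35.5 nM, and compound 3 `Cc1c(C(C)n2cnc3ncc(-c4cnn(CCO)c4)nc32)ccc2ncccc12` gives 726 nM. Compound 2 thus stands within the scatter of compound 1, and its number lies well under that of compound 3. Compound 4 `CC(c1c(F)cc2ncccc2c1F)n1cnc2ncc(-c3ccccc3)nc21` carries phenyl in place of 1-methyl-1H-pyrazol-4-yl on an aromatic carbon. For the measured compounds named here, the one measured single-place step, a 1.1-fold higher number from compound 1 to compound 2 (0.05 log units; within the scatter), concerns fluoro and not this group, so no measured step speaks to the swap directly. Compound 3, at 726 nM, differs from compound 2 in more than one place, but it shows that numbers in this assay can run much higher in this series. A moderate rise is therefore expected, an estimated 3.4-fold higher number from compound 2 to compound 4 (0.53 log units; beyond the scatter). Compound 4 is expected at 120 nM, within an estimated range of 35 nM to 500 nM.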

Compound 4, half-maximal inhibitory concentration: 514 nM
Compound 4: the middle estimate sits 4.3-fold (0.63 log units) below what was measured, and the stated range ends below it.
By their numbers in this assay, from the lowest: compounds 1 and 2 (each within the scatter of the next); then compounds 4 and 3 (each within the scatter of the next).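

At the aromatic carbon next to the ring nitrogen, this assay responds strongly to the ring carried there: phenyl in place of 1-methyl-1H-pyrazol-4-yl gives a 14-fold higher number from compound 2 to compound 4 (1.16 log units; beyond the scatter) as a large step, whereas the earlier single-place step, on fluoro, stayed within the scatter. The swap keeps 6 heavy atoms but goes from 2 hydrogen-bond acceptors to 0 and from a five-membered ring with 2 hetero atoms to a six-membered ring of carbon only. No data bearing on the cause of this step are available. Still open, as far as these compounds go, is whether a pyridyl ring, or a phenyl carrying an amine, would sit nearer compound 2 or compound 4 at this carbon.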